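From a Methoxyphenyl to a Sulfamoylphenyl: an Estimate

The source may report more compounds than this note shows. Statements on the series, on what has been measured and on what is new or still open speak of the compounds shown alone.

Measured compounds:
- compound 1, `COc1ccc(-n2nncc2CN2C(=O)C3(C(C#N)=C(N)Oc4c3c3nc5ccccc5nc3c3ccccc43)c3ccccc32)cc1`, in a functional assay on MCF7 cells (Homo sapiens) for antiproliferative activity, read by MTT assay, with a stated time of 48 h; a higher number here means a weaker inhibitor, a lower number a stronger inhibitor: > 50000 nM
- compound 2, `CCOc1ccc(-n2nncc2CN2C(=O)C3(C(C#N)=C(N)Oc4c3c3nc5ccccc5nc3c3ccccc43)c3ccccc32)cc1`, in this assay: > 50000 nM

Compound 1 stands at the edge of what this assay can report: the value given for compound 1 is a limit, not a number. The value for compound 2 is likewise a limit and not a number. Within the data shown here, the only step between measured compounds, a step that the two limits leave unreadable from compound 1 to compound 2, is therefore unreadable, and both values share the same position, (the limit of > 50000 nM in this assay, at which 2 of the 2 values shown sit).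

Compound 3, `N#CC1=C(N)Oc2c(c3nc4ccccc4nc3c3ccccc23)C12C(=O)N(Cc1cnnn1-c1cccc(S(N)(=O)=O)c1)c1ccccc12`, differs from compound 1 by 3-sulfamoylphenyl in place of 4-methoxyphenyl on an aromatic nitrogen. Among the measured compounds shown here, no measured step bears on this change, and the one step in hand tells nothing about its size or direction. The numbers give no reason to expect compound 3 to move beyond the scatter away from where compound 1 stands, but they also cannot rule out a gain in this assay.

Compound 3 is therefore expected to give about 60000 nM in this assay, within a range from 15000 nM to 250000 nM, most likely again as a limit. The step this estimate implies, a step that the limit leaves unreadable from compound 1 to compound 3, is expected to be small.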

Compound 3, half-maximal inhibitory concentration: 42500 nM
For compound 3 the middle estimate is 1.4-fold (0.15 log units) above the measured one, within the range that was stated.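

In this assay compound 3 is the only one of the compounds shown that gives a number rather than a limit, so the group on this aromatic nitrogen can bring a reading inside what the assay reports. That number gives the change a floor and a direction but not a size: 3-sulfamoylphenyl in place of 4-methoxyphenyl is an at least 1.1-fold lower number from compound 1 to compound 3 (0.07 log units; that floor lies within the scatter), and 3-sulfamoylphenyl in place of 4-ethoxyphenyl is an at least 1.1-fold lower number from compound 2 to compound 3 (0.07 log units; that floor lies within the scatter). Both floors lie within the scatter, so the change may be no more than that, the step between the two alkoxy compounds still cannot be read, and compound 1 and compound 2 remain limits, not numbers: the limit of > 50000 nM in this assay, at which 2 of the 3 values shown sit.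

From the compounds shown here alone, how far compound 3 truly stands from compound 1 stays open, as does whether the sulfamoyl group itself or its place on the phenyl ring carries the step. The compounds shown also leave open what a carboxylic acid or an amine in place of the sulfamoyl group would give in this assay.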